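The compounds below may be only part of what the source reports. "The series", "measured", "known", "first", "only" and "open" are said of these compounds alone.

In a functional assay on MCF7 cells (Homo sapiens) for antiproliferative activity, read by sulforhodamine B assay, with a stated time of 48 h (a higher number here means a weaker inhibitor of growth, a lower number a stronger inhibitor of growth), compound 1, whose structure is `O=C(NCc1cn(Cc2ccc(Cl)cc2)nn1)c1cn(-c2ccccc2)nc1-c1ccccc1`, gives > 100000 nM, which is a limit of the assay rather than a number. Compound 2, `COc1ccc(-c2nn(-c3ccccc3)cc2C(=O)NCc2cn(Cc3ccc(Cl)cc3)nn2)cc1`, differs from compound 1 by methoxy in place of hydrogen on an aromatic carbon and in this assay compound 2 gives 2900 nM; that change made an at least 34-fold lower number from compound 1 to compound 2 (1.53 log units; beyond the scatter). Compound 3, `COc1ccc(Cn2cc(CNC(=O)c3cn(-c4ccccc4)nc3-c3ccc(OC)cc3)nn2)cc1`, carries a different group on the benzyl part, and in this assay compound 3 gives 22900 nM, so that the step is a 7.9-fold higher number from compound 2 to compound 3 (0.90 log units; beyond the scatter). Compound 4, `COc1ccc(-c2nn(-c3ccccc3)cc2C(=O)NCc2cn(Cc3ccc(OC)c(OC)c3)nn2)cc1`, has not yet been measured. It differs from compound 3 by methoxy in place of hydrogen on an aromatic carbon, the same kind of change as that from compound 1 to compound 2, but the place is not the same: there the new group sat para to a large group, here it sits ortho to a methoxy group and meta to a large group. The difference between the two cores, compound 1 and compound 3, is not broken down here. Against the earlier at least 34-fold lower number from compound 1 to compound 2 (1.53 log units; beyond the scatter), a smaller step is expected, a 1.5-fold lower number from compound 3 to compound 4 (0.18 log units; within the scatter), because the methoxy behind an at least 34-fold lower number from compound 1 to compound 2 (1.53 log units; beyond the scatter) entered a different ring; compound 4 is estimated at 15000 nM, likely within 4000 nM and 50000 nM.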

Compound 4, concentration for 50% growth inhibition: > 100000 nM
Compound 4: only a limit was reported (the forecaster's own chance of this, stated with the estimate: 5%); at least 6.6-fold (0.82 log units) between middle value and limit.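

In this assay compound 4 gives > 100000 nM, which is a limit of the assay and not a number. Adding one more methoxy to the benzyl part gives an at least 4.3-fold higher number from compound 3 to compound 4 (0.64 log units; beyond the scatter), and 3,4-dimethoxyphenyl in place of 4-chlorophenyl gives an at least 34-fold higher number from compound 2 to compound 4 (1.53 log units; beyond the scatter), so the improvement seen earlier with a methoxy did not carry over, and the same kind of change moved the number in opposite directions on the two cores: the same change on two cores in this assay, an at least 34-fold lower number (1.53 log units; beyond the scatter) from compound 1 to compound 2 and an at least 4.3-fold higher number (0.64 log units; beyond the scatter) from compound 3 to compound 4, at least 150-fold (2.17 log units) apart, beyond the scatter of two such steps This does not show the true size of either step, nor how one methoxy behaves on the same ring of both cores, as the two methoxy groups entered different rings and both compound 1 and compound 4 give only a limit: the limit of > 100000 nM in this assay, at which 2 of the 4 values shown sit.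

As far as these compounds go, it stays open whether the 3,4-dimethoxybenzyl group would also give a limit on the core of compound 1. What a hydroxy group or a fluorine at the new place on the benzyl ring would give is also left open.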